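From 3-aminophenyl to 4-chlorophenyl on the shared core

A few compounds are considered here, and "the series" means these few. Any claim that something is new, unique, unknown or untested is made for them only; others in the source may bear on it.

Compound 1 `COc1cc(-n2cnc3ccc(-c4ccc(C)cc4F)cc32)cc(OC)c1OC`: > 10000 nM (a limit)
Compound 2 `COc1ccc(-c2ccc3ncn(-c4cc(OC)c(OC)c(OC)c4)c3c2)cc1F`: 1430 nM
Compound 3 `COc1cc(-n2cnc3ccc(-c4cccc(N)c4)cc32)cc(OC)c1OC`: 640 nM

In a functional assay on A549 cells (Homo sapiens) for antiproliferative activity, read by MTT assay, with a stated time of 72 h (on this read-out lower numbers stand for stronger inhibition and higher numbers for weaker inhibition), compound 3 gives 640 nM, the lowest of the two actual numbers. Its nearest neighbour is compound 2 at 1430 nM. Compound 1 gives > 10000 nM, which is a limit.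

Compound 4 `COc1cc(-n2cnc3ccc(-c4ccc(Cl)cc4)cc32)cc(OC)c1OC` carries 4-chlorophenyl in place of 3-aminophenyl on an aromatic carbon. Among the measured compounds shown here, two measured steps bear on this change, both of them arriving at 3-aminophenyl: a 2.2-fold lower number from compound 2 to compound 3 (0.35 log units; beyond the scatter) and an at least 15-fold lower number from compound 1 to compound 3 (1.19 log units; beyond the scatter). Losing 3-aminophenyl is therefore expected to raise the number in this assay, by a modest to large step. The expected change is a 3.9-fold higher number from compound 3 to compound 4 (0.59 log units; beyond the scatter). For compound 4 the estimated value is 2500 nM, with an expected range of 700 nM to 9000 nM.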

Compound 4, half-maximal inhibitory concentration: > 10000 nM
Compound 4: no number, only a limit (the forecaster's own chance of this, stated with the estimate: 20%); middle value at least 4.0-fold (0.60 log units) away from the limit.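

In this assay, among the compounds shown here, this position proves less forgiving than the earlier compounds showed: 4-chlorophenyl gives an at least 15-fold higher number from compound 3 to compound 4 (1.19 log units; beyond the scatter), and against 3-fluoro-4-methoxyphenyl it gives an at least 6.9-fold higher number from compound 2 to compound 4 (0.84 log units; beyond the scatter). Among these four compounds, 4-chlorophenyl thus joins 2-fluoro-4-methylphenyl at the limit, while 3-aminophenyl and 3-fluoro-4-methoxyphenyl keep actual numbers. Compound 4 gives only a limit, as compound 1 does, and the step between them cannot be read: the limit of > 10000 nM in this assay, at which 2 of the 4 values shown sit.

Still open, as far as these compounds go, is whether the lowest number goes with the amine itself or with its place on the ring. 4-Aminophenyl, 3-chlorophenyl or 3-hydroxyphenyl would separate the two.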